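This account rests on a few compounds, and the source may have more. Where it says the series, first, only, none or still open, it means among the compounds named here.

- Compound 1 `Cc1ccc(S/C(=C/c2sccc2C)C(=O)c2ccc(Br)cc2)cc1`: 50000 nM
- Compound 2 `Cc1ccc(S/C(=C/c2ccc(F)c(C)c2)C(=O)c2ccc(Br)cc2)cc1`: 25000 nM
- Compound 3 `CSc1ccc(/C=C(/Sc2ccc(C)cc2)C(=O)c2ccc(Br)cc2)cc1`: 50000 nM

These values come from a functional assay on DU-145 cells (Homo sapiens) for inhibition, read by trypan blue exclusion, with a stated time of 96 h; a higher number here means a weaker inhibitor of growth, a lower number a stronger inhibitor of growth. Compound 3 stands level with compound 1, and all three values lie within the scatter of one another. Compound 4 `Cc1ccc(S/C(=C/c2ccc(C)s2)C(=O)c2ccc(Br)cc2)cc1` has not yet been measured. It departs from compound 3 at a single place: 5-methylthiophen-2-yl in place of 4-(methylsulfanyl)phenyl on a double-bonded chain carbon bound to a double-bonded chain carbon. There, 5-methylthiophen-2-yl replaces 4-(methylsulfanyl)phenyl on a double-bonded chain carbon bound to a double-bonded chain carbon.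

Three measured steps changed the group at this same place: a 2.0-fold lower number from compound 1 to compound 2 (0.30 log units; within the scatter), a 2.0-fold higher number from compound 2 to compound 3 (0.30 log units; within the scatter) and no change at the digits printed from compound 1 to compound 3 (within the scatter). All three stayed within the scatter. Among the measured compounds shown here, the last bears most directly, since compound 1 also carries a methyl-substituted thiophene there, though none of the measured compounds holds the new group itself. No step beyond the scatter is therefore expected in this assay, and no clear direction can be drawn from these data. The expected change is a 1.3-fold lower number from compound 3 to compound 4 (0.10 log units; within the scatter). For compound 4 the estimated value is 40000 nM, with an expected range of 15000 nM to 80000 nM.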

Compound 4, concentration for 50% growth inhibition: > 100000 nM
Compound 4: no number, only a limit; the forecaster's own chance of this, stated with the estimate: 25%; middle value at least 2.5-fold (0.39 log units) from the limit.
By their numbers in this assay, from the lowest: compounds 2, 1 and 3 (each within the scatter of the next). At a limit, above all of these: compound 4.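

In this assay compound 4 reads > 100000 nM, which is a limit of the assay and not a number: the limit of > 100000 nM in this assay, at which 1 of the 4 values shown sits. At this place, on a double-bonded chain carbon bound to a double-bonded chain carbon, earlier changes had stayed within the scatter, whereas 5-methylthiophen-2-yl now gives a step beyond it, with an at least 4.0-fold higher number from compound 2 to compound 4 (0.60 log units; beyond the scatter). The other two steps, an at least 2.0-fold higher number from compound 3 to compound 4 (0.30 log units; that floor lies within the scatter) and an at least 2.0-fold higher number from compound 1 to compound 4 (0.30 log units; that floor lies within the scatter), have floors within the scatter, so neither separates the pair it joins.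

The compounds shown leave open how much of this result rests on the methyl of 5-methylthiophen-2-yl, and how an unsubstituted thiophen-2-yl would read at this place. They also leave open how a 4-(dimethylamino)phenyl or a 4-carboxyphenyl group would read there.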